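The source may hold more compounds than are shown below. What is called first, only, known or untested is meant among the compounds shown, and "the series" means these compounds.

Compound 1 `C=Cc1ccc(S(=O)(=O)Nc2ccc(-c3nc4ccccc4o3)cc2)cc1`: > 100000 nM, a limit
Compound 2 `O=S(=O)(Nc1ccc(-c2nc3ccccc3o2)cc1)c1ccc(F)cc1`: > 100000 nM, a limit
Compound 3 `COc1cccc(S(=O)(=O)Nc2ccc(-c3nc4ccccc4o3)cc2)c1`: > 100000 nM, a limit

In an ADME assay on HEK293 cells (Homo sapiens) for cytotoxicity, read by resazurin assay, with a stated time of 48 h (a higher number here means that more compound is tolerated, a lower number that less compound is tolerated), compound 3 gives > 100000 nM, which is a limit and not a number. Compound 3 therefore has no exact value and stands with compound 1 and compound 2 at the limit of > 100000 nM in this assay, at which 3 of the 3 values shown sit.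

Compound 4 `COc1ccc(Cl)cc1S(=O)(=O)Nc1ccc(-c2nc3ccccc3o2)cc1` keeps the shared core and alters one group: 5-chloro-2-methoxyphenyl in place of 3-methoxyphenyl on a sulfonyl sulfur. In words, 5-chloro-2-methoxyphenyl takes the place of 3-methoxyphenyl on a sulfonyl sulfur.

Two measured steps also exchange the group on the sulfonyl sulfur: a step that the two limits leave unreadable from compound 1 to compound 3 and a step that the two limits leave unreadable from compound 2 to compound 3. A third exchanges a group on the same aromatic ring: a step that the two limits leave unreadable from compound 1 to compound 2. None of the three has a size that can be read, so they offer no measured direction for the new change. Within the data shown here, every compound measured so far reached the same limit, so no step beyond the usual scatter is expected in this assay. However, compound 4 carries a chlorine that none of the measured compounds has, so the estimate leaves some room on the low side.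

The expected change is a number no higher from compound 3 to compound 4 (the limit leaves the size open). The estimate for compound 4 is 100000 nM, with an expected range from 40000 nM to 150000 nM. The most likely outcome is that the assay again reports only a limit.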

Compound 4, half-maximal cytotoxic concentration: 75000 nM
Compound 4: middle estimate off by 1.3-fold (0.12 log units), on the high side; low and high end bracket the measured number.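

In this assay, among these compounds, the exchange on the sulfonyl sulfur yields the first exact number of the series, which shows that a group at this place can bring the reading down from the limit to a measurable value. That reading gives an at least 1.3-fold lower number from compound 3 to compound 4 (0.12 log units; that floor lies within the scatter), an at least 1.3-fold lower number from compound 2 to compound 4 (0.12 log units; that floor lies within the scatter) and an at least 1.3-fold lower number from compound 1 to compound 4 (0.12 log units; that floor lies within the scatter), so each step has a floor but no upper bound, and that floor alone does not show a change beyond the usual scatter. The earlier steps among compound 1, compound 2 and compound 3 still cannot be read, and compound 4 is the only one with a true number, so it stands apart from the rest of the series: the limit of > 100000 nM in this assay, at which 3 of the 4 values shown sit.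

The compounds shown do not separate the part played by the chlorine from that of the methoxy group in 5-chloro-2-methoxyphenyl, since no compound carries one without the other on that ring. As far as these compounds go, it also remains open how an amine or a carboxylic acid on the same ring would read, and whether any such group would take the number clearly beyond the scatter.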